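The compounds below may be only part of what the source reports. "The series", "measured", "known", "first", "only" and "open" are said of these compounds alone.

Measured so far:
Compound 1 `CC(C)(C)OC(=O)/C=C1/C(=O)Nc2ccccc21` — in a functional assay on HL-60 cells (Homo sapiens) for inhibition, read by CCK-8 assay, with a stated time of 72 h, tested at 20 uM (on this read-out lower numbers stand for less inhibition of growth and higher numbers for more inhibition of growth at the one concentration tested), compound 1 gives 94.5%
Compound 2 `Cc1ccc2c(c1)/C(=C\C(=O)OC(C)(C)C)C(=O)N2` — in this assay compound 2 gives 94.6%

On these numbers compound 1 stands lowest of the two, with compound 2 nearest; the two values lie within the scatter of each other, so they count as the same result. For the measured compounds named here, the one measured step, a number 0.1 percentage points higher from compound 1 to compound 2 (within the scatter), is within the scatter. Compound 3 `COc1cccc2c1NC(=O)/C2=C/C(=O)OC(C)(C)C` has not yet been measured. It differs from compound 1 in one place: methoxy in place of hydrogen on an aromatic carbon. Going by the values given here, the only step that bears on this change is the one from compound 1 to compound 2, where a methyl replacing a hydrogen on an aromatic carbon changed nothing beyond the scatter; a methoxy is a different group, so that step is a guide, not proof. No step beyond the scatter is expected in this assay. Compound 3 is therefore estimated at 93%, with a range from 84% to 98%, meaning an expected step of a number 1.5 percentage points lower from compound 1 to compound 3 (within the scatter).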

Compound 3, percent growth inhibition at one concentration: 84.2%
Compound 3: middle estimate off by 8.8 percentage points, on the high side; the range from low to high includes it.
By their numbers in this assay, from the lowest: compound 3; then compounds 1 and 2 (each within the scatter of the next).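

In this assay the change to methoxy brings a number 10.3 percentage points lower from compound 1 to compound 3 (beyond the scatter) and is the first step beyond the scatter among the compounds shown. A methyl on an aromatic carbon brought only a number 0.1 percentage points higher from compound 1 to compound 2 (within the scatter) so the earlier pair gave no sign that a single added group on this part of the shared core could move the read-out at all. No measurement here explains why the methoxy compound reads lower.

Going by these compounds, it remains open whether a hydroxy, a fluorine or a longer chain such as ethoxy at this same place would stay level with compound 1 or fall further. On these data alone, with each compound tested at one concentration, it is also open whether this modest step would hold at other concentrations.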